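A few compounds are considered here, and "the series" means these few. Any claim that something is new, unique, unknown or untested is made for them only; others in the source may bear on it.

Working notes on a small set of styryl-linked six-membered cores. In a functional assay on MCF7 cells (Homo sapiens) for inhibition, read by sulforhodamine B assay, with a stated time of 48 h (on this read-out higher numbers stand for weaker inhibition of growth and lower numbers for stronger inhibition of growth), compound 1 `COc1ccc(/C=C/C2CC(=O)C=CO2)cc1OC` gives 130 uM and compound 2 `COc1cc(/C=C/C2CC(=O)C=CO2)cc(OC)c1OC` gives 149 uM, the highest of the three numbers; the step of a 1.1-fold higher number from compound 1 to compound 2 (0.06 log units; within the scatter). Compound 3 `O=C1C=CCC(/C=C/c2ccccc2C(F)(F)F)O1` gives 50.4 uM, the lowest number, and its gap to compound 2 is beyond the scatter. Compound 4 `COc1cc(/C=C/C2CC=CC(=O)N2)cc(OC)c1OC` awaits measurement; it differs from compound 2 by a group of 7 heavy atoms (5 carbon, 1 nitrogen, 1 oxygen; one six-membered non-aromatic ring with 1 hetero atom) in place of a group of 7 heavy atoms (5 carbon, 2 oxygen; one six-membered non-aromatic ring with 1 hetero atom), on a double-bonded chain carbon bound to a double-bonded chain carbon. Among the measured compounds shown here, no measured step touches this part of the structure: the only step on record, a 1.1-fold higher number from compound 1 to compound 2 (0.06 log units; within the scatter), concerns a methoxy on an aromatic carbon and lies within the scatter, so it gives no direction. The step of a 1.0-fold higher number from compound 2 to compound 4 (0.00 log units; within the scatter) is therefore expected to stay within the scatter. For compound 4 the estimate is 150 uM, range 50 uM to 450 uM.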

Compound 4, concentration for growth inhibition (reported as GI): > 864 uM
Compound 4: no number, only a limit; the forecaster's own chance of this, stated with the estimate: 15%; middle value at least 5.7-fold (0.76 log units) away from the limit.
By their numbers in this assay, from the lowest: compound 3; then compounds 1 and 2 (each within the scatter of the next). At a limit, above all of these: compound 4.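

Exchanging the ring of 5 carbon and 2 oxygen atoms for the ring of 5 carbon, 1 nitrogen and 1 oxygen atoms, on a double-bonded chain carbon bound to a double-bonded chain carbon, gives an at least 5.7-fold higher number from compound 2 to compound 4 (0.76 log units; beyond the scatter) in this assay. Among the compounds shown here, this is the first step that lies beyond the scatter and touches this part of the structure. Compound 4 is recorded only as a limit, not a number, so the full size of the step stays unknown: the limit of > 864 uM in this assay, at which 1 of the 4 values shown sits.

Going by these compounds, it remains open whether the same ring exchange gives a similar step alongside the trifluoromethyl group of compound 3. Also open, on these data alone, is what a methyl group in place of the amide hydrogen would do.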